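The source may report more compounds than this note shows. Statements on the series, on what has been measured and on what is new or still open speak of the compounds shown alone.

Measured so far in an assay for inhibition of Fatty-acid amide hydrolase 1 (Rattus norvegicus), using a Dixon plot; a higher number here means a weaker inhibitor, a lower number a stronger inhibitor:
compound 1 `O=C(c1ncco1)C1CCc2cc(Oc3ccccc3)ccc2O1` gives 17 nM; 31 nM (2 entries) (the several entries of compound 1 in this assay, 17 nM; 31 nM (2 entries))
compound 2 `O=C(c1ncco1)[C@H]1COc2cc(OCc3ccccc3)ccc2C1` gives 20 nM
compound 3 `O=C(c1ncc(-c2ccccn2)o1)[C@H]1COc2cc(Oc3ccccc3)ccc2C1` gives 18 nM

Compound 3 stands close to compound 2, within the scatter of this assay, and the two entries of compound 1 scatter around the same region. All three sit in the same narrow band.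

Compound 4 `O=C(c1ncc(-c2ccccn2)o1)[C@H]1COc2cc(OCc3ccccc3)ccc2C1` has not yet been measured. It differs from compound 3 by benzyl in place of phenyl on an oxygen on an aromatic ring. Compound 2 already carries the benzyloxy group and sits within the scatter of compound 3, so no step beyond the scatter is expected in this assay for compound 4. The expected step of a 1.1-fold lower number from compound 3 to compound 4 (0.05 log units; within the scatter) is small. Compound 4 is estimated at 16 nM, with a range from 5 nM to 50 nM.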

Compound 4, inhibition constant: 18 nM
Compound 4: middle estimate off by 1.1-fold (0.05 log units), on the low side, and the stated range covers the measured number.
By their numbers in this assay, from the lowest: compounds 3, 4 and 2 (each within the scatter of the next).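

With pyridin-2-yl on the core, benzyl in place of phenyl on an oxygen on an aromatic ring gives no change at the digits printed from compound 3 to compound 4 (within the scatter) in this assay and so leaves the number in the same band. Among the compounds shown here, with benzyloxy held, pyridin-2-yl in place of hydrogen on an aromatic carbon gives a 1.1-fold lower number from compound 2 to compound 4 (0.05 log units; within the scatter) in the same read-out, the first single-place reading of this group. The repeat entries of one compound span a wider gap than either step: the several entries of compound 1 in this assay, 17 nM; 31 nM (2 entries).

Going by these compounds, whether phenethyl in place of benzyl on that oxygen, or an amine or a carboxylic acid in place of pyridin-2-yl, stays in this band remains open.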